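Swapping the Amide Substituent of Compound 1: An Expectation

The source may hold more compounds than are shown below. What is called first, only, known or untested is meant among the compounds shown, and "the series" means these compounds.

Compound 1 `N[C@H]1CC[C@H](Nc2c(C(=O)NCc3ccco3)nc(Br)c3cccnc23)CC1` was tested in a functional assay on MDA-MB-435 cells (Homo sapiens) for cytotoxicity, read by MTT assay, with a stated time of 72 h (a higher number here means a weaker inhibitor, a lower number a stronger inhibitor), where compound 1 gives > 10000 nM, which is a limit of the assay rather than a number. Compound 2 `O=C(NCc1ccc(F)cc1)c1nc(Br)c2cccnc2c1N1CCNCC1` gives 8000 nM in this assay. Compound 3 `Cc1ccc(S(=O)(=O)Oc2c(C(=O)NCc3ccc(F)cc3)nc(Br)c3cccnc23)cc1` gives > 20000 nM, again a limit of the assay. For the measured compounds named here, the one measured step, an at least 2.5-fold higher number from compound 2 to compound 3 (0.39 log units; beyond the scatter), alters a group on an aromatic carbon, not the amide nitrogen. Compound 4 `N[C@H]1CC[C@H](Nc2c(C(=O)Nc3ccccc3)nc(Br)c3cccnc23)CC1` differs from compound 1 by phenyl in place of (furan-2-yl)methyl on an amide-type nitrogen. Going by the values given here, no measured step touches that position, so nothing here points to a shift beyond the scatter. Compound 4 is therefore expected to stay near the limit region, a step that the limit leaves unreadable from compound 1 to compound 4. The estimate for compound 4 is 15000 nM, ranging from 5000 nM to 50000 nM, with a limit the likeliest outcome.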

Compound 4, half-maximal inhibitory concentration: 1000 nM
The estimate for compound 4 lay 15-fold (1.18 log units) above the measured number, and the stated range ends above it.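

Phenyl in place of (furan-2-yl)methyl on the amide-type nitrogen gives an at least 10-fold lower number from compound 1 to compound 4 (1.00 log units; beyond the scatter) in this assay, which shows that this position, untouched by the earlier measured step, does bear on the read-out. Compound 1 stands at a limit, so the step marks only a minimum and its full size stays unread: the limit of > 10000 nM in this assay, at which 1 of the 4 values shown sits. The compounds shown leave open whether the change depends on the ring itself or on the loss of the methyl link. A furan-2-yl group set directly on that nitrogen, or a benzyl group there, would separate the two.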